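The source may report more compounds than this note shows. Statements on the series, on what has been measured and on what is new or still open speak of the compounds shown alone.

Going by the values given here, compound 2 `CCN(CCCn1sc2cc(OC)c(OC)cc2c1=O)Cc1ccccc1OC` is one of two compounds measured in an assay on isolated protein for inhibition of Amine oxidase [flavin-containing] A (Homo sapiens), read by fluorescence, with a stated time of 30 min; on this read-out lower numbers stand for stronger inhibition and higher numbers for weaker inhibition. There compound 2 gives 15500 nM, the higher of the two numbers shown, although its only neighbour, compound 1 `COc1ccccc1CN(C)CCCn1sc2cc(OC)c(OC)cc2c1=O`, gives 9400 nM and a 1.6-fold higher number from compound 1 to compound 2 (0.22 log units; within the scatter) lies within the scatter, so the two cannot be told apart. Compound 3 `CCN(CCCn1sc2cc(OC)c(OC)cc2c1=O)Cc1ccc(N(C)C)cc1` has not yet been measured. It differs from compound 2 in one place: 4-(dimethylamino)phenyl in place of 2-methoxyphenyl on a saturated chain carbon bound to an amine nitrogen. Among the compounds with values here, no measured step bears on this change; the single step on hand, from compound 1 to compound 2, concerns a different part of the molecule and was itself within the scatter. With nothing to set a direction, compound 3 is expected to land near compound 2, and the step of a 1.0-fold lower number from compound 2 to compound 3 (0.01 log units; within the scatter) is expected to stay within the scatter. The estimate for compound 3 in this assay is therefore 15000 nM, with a range from 4000 nM to 60000 nM.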

Compound 3, half-maximal inhibitory concentration: 11300 nM
Compound 3: the middle estimate sits 1.3-fold (0.12 log units) above what was measured; measured number inside the range.
By their numbers in this assay, from the lowest: compounds 1, 3 and 2 (each within the scatter of the next).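

Going by these compounds alone, replacing 2-methoxyphenyl with 4-(dimethylamino)phenyl is the first change at this place, on a saturated chain carbon bound to an amine nitrogen, to be read in this assay. The result, a 1.4-fold lower number from compound 2 to compound 3 (0.14 log units; within the scatter), lies within the scatter, so compound 2 and compound 3 cannot be told apart, and this position has tolerated this exchange of aromatic groups without a readable change in the number. No measurement on hand offers an explanation for this result.

As far as these compounds go, it remains open whether 4-methoxyphenyl or 2-(dimethylamino)phenyl at this place, or a carboxylic acid on the ring, would move the number beyond the scatter. Also open, from the compounds shown here alone, is what a longer chain leading to the shared core would do in this assay.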